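The source may hold more compounds than are shown below. What is called first, only, known or untested is meant among the compounds shown, and "the series" means these compounds.

Of the compounds shown here, three of a shared core have been measured in an assay on isolated protein for inhibition of Dihydrofolate reductase (Mus musculus); on this read-out higher numbers stand for higher potency (the scale is a negative logarithm) and lower numbers for lower potency. Compound 1 `CC1(C)N=C(N)N=C(N)N1c1ccc(CC(C(=O)Nc2ccc(S(=O)(=O)F)cc2)c2cccc3ccccc23)cc1` gives 6.24, compound 3 `CC1(C)N=C(N)N=C(N)N1c1ccc(SCCC(=O)Nc2ccc(S(=O)(=O)F)cc2)c(Cl)c1` gives 7.39, and compound 2 `CC1(C)N=C(N)N=C(N)N1c1cccc(CCc2ccccc2)c1` gives 8.19. Compound 2 therefore stands highest of the three: its nearest neighbour, compound 3, lies lower by a gap beyond the scatter, and compound 1 lies further below it, also beyond the scatter. Both of the weaker compounds carry a long, heavily substituted side chain, whereas compound 2 carries a short one.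

Compound 4 `CC1(C)N=C(N)N=C(N)N1c1cccc(CCCCOc2ccccc2)c1` has not yet been measured in this assay. It differs from compound 2 in one place: 2-phenoxyethyl in place of phenyl on a saturated chain carbon, two bonds along the chain from an aromatic carbon. The change lengthens the side chain and adds an oxygen to it. Among the compounds with values here, no measured pair in this set isolates such a change, so the expectation rests on the general observation that the two longer-chained compounds sit below compound 2. A modest downward step in this assay is expected, a number 0.49 log units lower from compound 2 to compound 4 (beyond the scatter), beyond the scatter but smaller than the gap to compound 3. Compound 4 is thus estimated at 7.7, within a range of 7 to 8.4.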

Compound 4, logarithm of the reciprocal of the active concentration, log(1/C): 8.35
Compound 4: middle estimate off by 0.65 log units, on the low side; the range from low to high includes it.
By their numbers in this assay, from the lowest: compound 1; then compound 3; then compounds 2 and 4 (each within the scatter of the next).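

In this assay, 2-phenoxyethyl in place of phenyl on a saturated chain carbon, two bonds along the chain from an aromatic carbon, gives a number 0.16 log units higher from compound 2 to compound 4 (within the scatter). Within the data shown here, this position therefore accepts the larger group, with 9 heavy atoms against 6 and one oxygen, without a change that stands clear of the scatter, something the earlier compounds could not show, as neither differs from compound 2 in one place only. Nothing at hand explains why the two groups read alike.

Compound 4 brings in the added chain carbons and the oxygen together, and the compounds shown do not separate the two. As far as these compounds go, what a longer chain, or an amine or a carboxylic acid at its end, would do at this position stays open.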